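The source may hold more compounds than are shown below. What is called first, only, known or untested is meant among the compounds shown, and "the series" means these compounds.

Measured compounds:
compound 1, `C/C(COc1ccc2c(=O)cc(-c3ccccc3)oc2c1)=N\O`, 2800000 nM in a functional assay on SK-HEP1 cells (Homo sapiens) for antiproliferative activity; on this read-out higher numbers stand for weaker inhibition of growth and lower numbers for stronger inhibition of growth
compound 2, `CO/N=C(\C)COc1ccc2c(=O)cc(-c3ccccc3)oc2c1`, 2000000 nM in this assay

Compound 2 stands at the lower of the two numbers, yet the step of a 1.4-fold lower number from compound 1 to compound 2 (0.15 log units; within the scatter) shows this is not a separation that can be trusted. Compound 3, `O=c1cc(-c2ccccc2)oc2cc(OC/C(=N/O)c3ccccc3)ccc12`, has not yet been measured in this assay. Its change from compound 2 is a group of 9 heavy atoms (7 carbon, 1 nitrogen, 1 oxygen; one six-membered aromatic ring of carbon only) in place of a group of 5 heavy atoms (3 carbon, 1 nitrogen, 1 oxygen; no ring), on a saturated chain carbon bound to an oxygen on an aromatic ring. Among the measured compounds shown here, only one measured step exists, from compound 1 to compound 2, and it concerns a methyl on an oxygen, not a phenyl in place of a methyl on the oxime carbon; nothing measured speaks to the entering ring. For the measured compounds named here, since the one known step was within the scatter, no direction is supported for compound 3 beyond that scatter. The estimate for compound 3 is therefore a value near compound 2, 2000000 nM, in the range 400000 nM to 10000000 nM, and the expected step is no change at the digits printed from compound 2 to compound 3 (within the scatter), with a wide margin given the untested phenyl.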

Compound 3, concentration for 50% growth inhibition: 2000000 nM
Beside the measured number, compound 3's estimate shows no gap at the digits printed; measured number inside the range.
By their numbers in this assay, from the lowest: compounds 2, 3 and 1 (each within the scatter of the next).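

In this assay, among the compounds shown here, the ring enters without moving the read-out beyond the scatter: phenyl in place of methyl on a carbon with a double bond to nitrogen gives a 1.4-fold lower number from compound 1 to compound 3 (0.15 log units; within the scatter) and is the first reading of a ring at this place. The wider exchange, on a saturated chain carbon bound to an oxygen on an aromatic ring, gives no change at the digits printed from compound 2 to compound 3 (within the scatter) even though a group of 9 heavy atoms replaces a group of 5, so neither step shows this position responding to the added size. Nothing available bears on why the numbers stay together.

Still open, from the compounds shown here alone, is whether any other group on that carbon, such as an amine, a carboxylic acid or a longer chain, would give a step beyond the scatter. The compounds shown also leave open whether a change to the shared core would do so.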